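This account rests on a few compounds, and the source may have more. Where it says the series, first, only, none or still open, it means among the compounds named here.

Of the compounds shown here, three built on one shared core have been measured in an assay for inhibition of mitogen-activated protein kinase kinase kinase 14 (Homo sapiens), read by luminescence and ADP-Glo, with a stated time of 120 min, in the presence of a further agent that is not named here; a lower number here means a stronger inhibitor, a higher number a weaker inhibitor. Compound 1 `CC(O)(C#Cc1ccc(N2CCCC2)c(Nc2ncnc3[nH]ccc23)c1)c1nccs1` gives 107 nM. Compound 2 `C[C@@H]1CN(c2ccc(C#CC(C)(O)c3nccs3)cc2Nc2ncnc3[nH]ccc23)CCN1` gives 210 nM, and compound 3 `CC(O)(C#Cc1ccc(N2CC3CC2CN3)c(Nc2ncnc3[nH]ccc23)c1)c1nccs1` gives 200 nM. Among these three numbers compound 3 stands second highest, with compound 2 nearest and compound 1 furthest; the steps of a 1.9-fold higher number from compound 1 to compound 3 (0.27 log units; within the scatter) and a 1.1-fold lower number from compound 2 to compound 3 (0.02 log units; within the scatter) both lie within the scatter of repeated measurements, as does a 2.0-fold higher number from compound 1 to compound 2 (0.29 log units; within the scatter). So far, exchanging the saturated amine attached to the shared core has not produced a step beyond that scatter.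

Compound 4 `CN1CCCN(c2ccc(C#CC(C)(O)c3nccs3)cc2Nc2ncnc3[nH]ccc23)CC1` makes one more exchange at the same position: a group of 8 heavy atoms (6 carbon, 2 nitrogen; one seven-membered non-aromatic ring with 2 hetero atoms) in place of a group of 7 heavy atoms (5 carbon, 2 nitrogen; 2 five-membered non-aromatic rings with 1 hetero atom each), on an aromatic carbon. Going by the values given here, no measured step involves this incoming group, so the expectation rests on the three earlier exchanges of amine, which are the only steps that bear on it. Because each of a 2.0-fold higher number from compound 1 to compound 2 (0.29 log units; within the scatter), a 1.9-fold higher number from compound 1 to compound 3 (0.27 log units; within the scatter) and a 1.1-fold lower number from compound 2 to compound 3 (0.02 log units; within the scatter) stayed within the scatter, the expected step in this assay is no change at the digits printed from compound 3 to compound 4 (within the scatter), with no direction that should stand out beyond the scatter. Compound 4 is therefore estimated at 200 nM, in a range from 90 nM to 450 nM.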

Compound 4, half-maximal inhibitory concentration: 60.1 nM
Compound 4: the middle estimate sits 3.3-fold (0.52 log units) above what was measured; measured number outside the range, below it.
By their numbers in this assay, from the lowest: compounds 4, 1, 3 and 2 (each within the scatter of the next, the first and the last beyond it).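

In this assay, going by these compounds alone, the 4-methyl-1,4-diazepan-1-yl group gives the first exchanges at this position that clear the scatter, with a 3.3-fold lower number from compound 3 to compound 4 (0.52 log units; beyond the scatter) and a 3.5-fold lower number from compound 2 to compound 4 (0.54 log units; beyond the scatter). The position is therefore not indifferent to which saturated amine it carries, something the first three compounds could not show. The gain is only relative to those two partners, however: a 1.8-fold lower number from compound 1 to compound 4 (0.25 log units; within the scatter) leaves the seven-membered ring and the small pyrrolidin-1-yl group unresolved, so neither can be ranked above the other, and nothing measured here explains the separation from the other two amines.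

Compared with compound 2, compound 4 differs in both ring size and the place of the methyl group, so the compounds shown cannot say which of these matters, or whether the two act only together. The 4-methylpiperazin-1-yl group, which keeps the six-membered ring of compound 2 but moves its methyl, and the 1,4-diazepan-1-yl group, which keeps the seven-membered ring of compound 4 but has no methyl, would each help to pull these two changes apart.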